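Shortening the chain between the thioamide and the ring

The source may report more compounds than this note shows. Statements on the series, on what has been measured and on what is new or still open speak of the compounds shown alone.

Among the compounds with values here, compound 1 `N=C(S)CCCCCCN1N=C(c2ccccc2)CCC1=O` is the only member of this small set with a number in a functional assay on the whole organism (stomach) with Rattus norvegicus as the target; a higher number here means that more compound is needed for the effect, a lower number that less compound is needed: compound 1 gives 58.8 mg/kg. Compound 2 `CC1=NN(CCC(=N)S)C(=O)CC1` reaches only a limit there, > 100 mg/kg. Compound 3 `N=C(S)CCN1N=C(c2ccc(Cl)c(Cl)c2)CCC1=O` likewise stops at a limit, > 100 mg/kg. Thus (the limit of > 100 mg/kg in this assay, at which 2 of the 3 values shown sit). Compound 4 `N=C(S)CCCCCN1N=C(c2ccccc2)CCC1=O` has not yet been measured; it differs from compound 1 by a group of 3 heavy atoms (1 carbon, 1 nitrogen, 1 sulfur; no ring) in place of a group of 4 heavy atoms (2 carbon, 1 nitrogen, 1 sulfur; no ring), on a saturated chain carbon, five bonds along the chain from an amide-type nitrogen in a ring. Within the data shown here, no step between two measured compounds is available to calibrate a change of this kind, so one expects at most a small shift in this assay, within the usual scatter, with no clear direction. The estimate for compound 4 in this assay is 65 mg/kg, within a range of 25 mg/kg to 160 mg/kg. This amounts to an expected step of a 1.1-fold higher number from compound 1 to compound 4 (0.04 log units; within the scatter).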

Compound 4, dose for half-maximal effect: 100 mg/kg
Compound 4: the middle estimate sits 1.5-fold (0.19 log units) below what was measured; measured number inside the range.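

Replacing the group of 4 heavy atoms with the group of 3 heavy atoms, on a saturated chain carbon, gives a 1.7-fold higher number from compound 1 to compound 4 (0.23 log units; within the scatter) in this assay. This first step on the chain therefore does not separate the two compounds, and this position tolerates the change within the scatter. The number for compound 4 also coincides with the figure of the assay's limit: the limit of > 100 mg/kg in this assay, at which 2 of the 4 values shown sit.

What the compounds shown leave open is whether a longer chain than that of compound 1 would change the dose needed. Also open, as far as these compounds go, is how an amine or a carboxylic acid would compare with the thioamide.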